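Shortening the Side Chain on an Inactive Core

The source may report more compounds than this note shows. Statements on the series, on what has been measured and on what is new or still open speak of the compounds shown alone.

Compound 1 `Cn1cc(C2=C(c3nn(CCCn4cncn4)c4ncccc34)C(=O)NC2=O)c2ccccc21` is the starting point. In a functional assay on KB cells (Homo sapiens) for antiproliferative activity, read by MTT assay, with a stated time of 48 h (on this read-out higher numbers stand for weaker inhibition and lower numbers for stronger inhibition), compound 1 gives > 100000 nM, which is a limit of the assay rather than a measured number. Compound 2 `Cn1cc(C2=C(c3nn(CCCN4CCCCC4)c4ncccc34)C(=O)N(c3ccc(Cl)cc3)C2=O)c2ccccc21` shares the core; in this assay compound 2 gives > 100000 nM, also only a limit. For the measured compounds named here, the only evidence here is the limit of > 100000 nM in this assay, at which 2 of the 2 values shown sit. Compound 3 `Cn1cc(C2=C(c3nn(CCn4ccnc4)c4ncccc34)C(=O)NC2=O)c2ccccc21` differs from compound 1 by 1H-imidazol-1-yl in place of (1H-1,2,4-triazol-1-yl)methyl on a saturated chain carbon, two bonds along the chain from an aromatic nitrogen. Going by the values given here, with no measured step to build on, the expectation for compound 3 is a step of a number no higher from compound 1 to compound 3 (the limit leaves the size open) of no size beyond the scatter. Compound 3 is expected to give about 100000 nM, somewhere between 20000 nM and 300000 nM, most likely again only a limit.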

Compound 3, half-maximal inhibitory concentration: > 100000 nM
Compound 3 was reported as a limit; the forecaster's own chance of this, stated with the estimate: 70%; the middle value sits exactly at the limit.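

For the compounds shown here, compound 1 and compound 3 are both reported only as limits, and no step between them can be read. The compounds shown leave open whether any side chain on this core gives a measured number in this assay.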